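The compounds below may be only part of what the source reports. "The series", "measured", "known", "first", "only" and "open" are said of these compounds alone.

In a functional assay on HBL-100 cells (Homo sapiens) for antiproliferative activity, read by sulforhodamine B assay, with a stated time of 48 h (on this read-out higher numbers stand for weaker inhibition of growth and lower numbers for stronger inhibition of growth), compound 1 (`CCCCC(C#CC(=O)OC)O/C=C/C(=O)OC`) gives 250 nM, the lower of the two exact numbers available. Compound 2 (`C#CC(O/C=C/C(=O)OC)c1ccccc1`) gives 26000 nM, a gap from compound 1 well beyond the usual scatter. Compound 3 (`CC1CCC(C(C)C)C(OC(=O)C#CC(O/C=C/C(=O)OC2CC(C)CCC2C(C)C)C(C)C)C1`) reaches only a limit of the assay, > 100000 nM. Compound 4 (`COC(=O)C#CC(O/C=C/C(=O)OC)C(C)(C)C`), not yet measured, carries tert-butyl in place of butyl on a saturated chain carbon bound to an oxygen on an unsaturated carbon and a triple-bonded carbon. Within the data shown here, no measured pair isolates this change. Among the measured compounds shown here, compound 2, at 26000 nM, shows only that numbers can lie much higher in this set. In this assay, a moderate rise beyond the scatter is expected, estimated as a 6.0-fold higher number from compound 1 to compound 4 (0.78 log units; beyond the scatter). For compound 4, the estimated value is 1500 nM, with an expected range from 200 nM to 15000 nM.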

Compound 4, concentration for 50% growth inhibition: 1800 nM
Estimate against measurement, compound 4: 1.2-fold (0.08 log units) below, within the range that was stated.
By their numbers in this assay, from the lowest: compound 1; then compound 4; then compound 2. At a limit, above all of these: compound 3.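

Among these compounds, this is the first reading of a change at this position, a saturated chain carbon bound to an oxygen on an unsaturated carbon and a triple-bonded carbon. In this assay, tert-butyl in place of butyl gives a 7.2-fold higher number from compound 1 to compound 4 (0.86 log units; beyond the scatter), so with the same atoms joined differently, the branching of the chain alone moves the number beyond the scatter. Nothing shown here accounts for this step. On these data alone, whether a shorter chain such as methyl, a longer chain such as hexyl, or an amine at this position would lower or raise the number remains open.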